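The source may report more compounds than this note shows. Statements on the series, on what has been measured and on what is new or still open speak of the compounds shown alone.

Of the compounds shown here, two have been measured in a functional assay on HL-60 cells (Homo sapiens) for antiproliferative activity, with a stated time of 24 h; a higher number here means a weaker inhibitor, a lower number a stronger inhibitor. Compound 1 `NC(=O)c1c(NC(=O)c2ccccc2Cl)sc2c1CCN(C(=S)Nc1cccnc1)C2` gives 33900 nM. Compound 2 `NC(=O)c1c(NC(=O)c2ccccc2I)sc2c1CCN(C(=S)Nc1ccccc1Cl)C2` gives 8560 nM, the lower of the two numbers and therefore the stronger inhibitor, with compound 1 standing clearly higher, beyond the usual scatter of repeated runs. Compound 3 `CSc1ccccc1C(=O)Nc1sc2c(c1C(N)=O)CCN(C(=S)Nc1ccccc1Cl)C2` is not yet measured. It differs from compound 2 in a single place: methylsulfanyl in place of iodo on an aromatic carbon. Among the measured compounds shown here, the two measured compounds differ from each other in more than one place, so they offer no step of comparable kind to lean on, and the size of this exchange can only be guessed. The expectation is a small step, in either direction, most likely within the scatter. In this assay compound 3 is estimated at 10000 nM, with a range from 3000 nM to 33000 nM. This estimate implies an expected step of a 1.2-fold higher number from compound 2 to compound 3 (0.07 log units; within the scatter), too small to count as a real change.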

Compound 3, half-maximal inhibitory concentration: 30500 nM
Estimate against measurement, compound 3: 3.1-fold (0.48 log units) below, within the range that was stated.
By their numbers in this assay, from the lowest: compound 2; then compounds 3 and 1 (each within the scatter of the next).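

In this assay, among the compounds shown here, this is the first comparison that changes one place only, and it shows that the aromatic carbon ortho to a large group is sensitive to what it carries. Putting methylsulfanyl in place of iodo gives a 3.6-fold higher number from compound 2 to compound 3 (0.55 log units; beyond the scatter), a modest step but a real one, toward a weaker inhibitor. Nothing available explains this step, so it cannot be said which difference between the two groups matters.

As far as these compounds go, whether an amine, a methoxy group or a fluorine on this same carbon would match iodo or fall further behind it remains open. Also open, from the compounds shown here alone, is whether the same exchange would give a step of similar size on the background of compound 1.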